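The compounds below may be only part of what the source reports. "The series", "measured", "known", "first", "only" and "open" are said of these compounds alone.

Compound 1 `CCOC(=O)CN(Cc1ccccc1)c1nc(NCc2ccccc2)ncc1[N+](=O)[O-]` is measured in a functional assay on MCF7 cells (Homo sapiens) for antiproliferative activity, read by MTT assay, with a stated time of 48 h (on this read-out higher numbers stand for weaker inhibition and lower numbers for stronger inhibition), where compound 1 gives > 100000 nM, a figure that is a limit of the assay rather than a number. Compound 3 `COC(=O)CN(C)c1nc(Nc2ccccc2)ncc1[N+](=O)[O-]` likewise gives > 100000 nM, which is again a limit. Compound 2 `CCOC(=O)CNc1nc(NCc2ccccc2)ncc1[N+](=O)[O-]` gives a number in this assay, 52400 nM. Among the compounds with values here, the one step traced among the measured compounds is an at least 1.9-fold lower number from compound 1 to compound 2 (0.28 log units; that floor lies within the scatter), and this floor lies within the scatter, so it sets no clear direction. The relevant observation is the limit of > 100000 nM in this assay, at which 2 of the 3 values shown sit, which leaves compound 1 standing only at a limit. Compound 4 `CCOC(=O)CN(Cc1ccccc1)c1nc(Nc2cc(OC)c(OC)c(OC)c2)ncc1[N+](=O)[O-]` carries the change (3,4,5-trimethoxyphenyl in place of benzyl on a nitrogen on an aromatic ring). Within the data shown here, no measured step covers the swap of benzyl for 3,4,5-trimethoxyphenyl on that nitrogen, and both neighbouring limits leave the size of any move open. Compound 4 is therefore expected to shift by an at least 2.0-fold lower number from compound 1 to compound 4 (0.30 log units; that floor lies within the scatter) in this assay, with a fair chance that only a limit is again reported. The estimate for compound 4 is 50000 nM, between 10000 nM and 200000 nM.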

Compound 4, half-maximal inhibitory concentration: > 100000 nM
Compound 4: a limit, no number; the forecaster's own chance of this, stated with the estimate: 45%; at least 2.0-fold (0.30 log units) between middle value and limit.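

In this assay compound 4 gives > 100000 nM, which is a limit of the assay and not a number. Within the data shown here, compound 1 also stands at a limit, so no step between the two can be read: the limit of > 100000 nM in this assay, at which 3 of the 4 values shown sit. The compounds shown leave open whether 3,4,5-trimethoxyphenyl in place of benzyl on a nitrogen on an aromatic ring changes the antiproliferative activity at all.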